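The compounds below may be only part of what the source reports. "The series", "measured", "known", "first", "only" and "open" are said of these compounds alone.

Measured so far:
- compound 1 `O=C(/C=C/c1ccc2c(c1)B(O)OC2)c1ccccc1` — 2300 nM
- compound 2 `O=C(/C=C/c1ccc2c(c1)B(O)OC2)c1ccccc1F` — 2200 nM
- compound 3 `O=C(/C=C/c1ccc2c(c1)B(O)OC2)c1ccccc1O` — 16900 nM

Compound 3 carries the highest number of the three in a functional assay on MDA-MB-231 cells (Homo sapiens) for cytotoxicity, read by MTT assay, with a stated time of 48 h; on this read-out higher numbers stand for weaker inhibition and lower numbers for stronger inhibition. Its nearest neighbour is compound 1, with a 7.3-fold higher number from compound 1 to compound 3 (0.87 log units; beyond the scatter) separating them, and compound 2 lies a little further off, with a 7.7-fold higher number from compound 2 to compound 3 (0.89 log units; beyond the scatter). Between compound 1 and compound 2 the step is a 1.0-fold lower number from compound 1 to compound 2 (0.02 log units; within the scatter), so the hydrogen and fluoro substituents on the ketone-bearing ring cannot be told apart on these numbers, while the hydroxy stands clearly weaker.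

Compound 4 `COc1ccccc1C(=O)/C=C/c1ccc2c(c1)B(O)OC2` differs from compound 3 by methyl in place of hydrogen on an oxygen on an aromatic ring; cut one bond further out, the change reads hydroxy to methoxy. Within the data shown here, no measured step covers a methoxy substituent, so the expectation rests only on the observation that the hydroxy group, in compound 3, goes with a modest loss against compound 1 and compound 2. Capping that hydroxy with a methyl removes the group that went with the loss, but whether the number returns toward compound 1 or stays near compound 3 is not settled by any step shown. A step of modest size downward, a 2.8-fold lower number from compound 3 to compound 4 (0.45 log units; beyond the scatter), is therefore expected, with wide bounds on either side.

Compound 4 is estimated at 6000 nM in this assay, within a range from 1800 nM to 20000 nM.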

Compound 4, half-maximal inhibitory concentration: 3100 nM
Beside the measured number, compound 4's estimate is 1.9-fold (0.29 log units) above it, within the range that was stated.
By their numbers in this assay, from the lowest: compounds 2, 1 and 4 (each within the scatter of the next); then compound 3.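

In this assay, methyl in place of hydrogen on the oxygen gives a 5.5-fold lower number from compound 3 to compound 4 (0.74 log units; beyond the scatter), so the loss that goes with the hydroxy in compound 3 does not carry over to the methoxy in compound 4. The comparisons with the other two compounds give a 1.3-fold higher number from compound 1 to compound 4 (0.13 log units; within the scatter) and a 1.4-fold higher number from compound 2 to compound 4 (0.15 log units; within the scatter), which places hydrogen, fluoro and methoxy on this aromatic carbon within the scatter of one another. Having oxygen attached at this place therefore does not by itself go with the weaker number: among these four compounds, only the free hydroxy of compound 3 stands apart, and a single methyl on that oxygen is enough to remove the gap. No evidence at hand bears on what lies behind this difference.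

On these data alone, whether other groups on this aromatic carbon would follow the hydroxy or the methoxy remains open, with an amine, a carboxylic acid and an ethoxy as the obvious cases. Also open is whether hydroxy and methoxy would keep this relationship at another place on the same ring, since all the substituents shown share one place.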